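The source may report more compounds than this note shows. Statements on the series, on what has been measured and on what is new or still open speak of the compounds shown alone.

Working notes on the series, with values in a functional assay on HCT-116 cells (Homo sapiens) for inhibition, read by MTT assay, with a stated time of 72 h; a lower number here means a stronger inhibitor of growth, a higher number a weaker inhibitor of growth

- compound 1 `Cc1cc(CN2CCN(c3c(Br)cnc4[nH]c(-c5ccc(CN(C)C)cc5)nc34)CC2)no1` gives 230 nM
- compound 2 `O=C(CN1CCN(c2c(Br)cnc3[nH]c(-c4ccccc4)nc23)CC1)Nc1nccs1` gives 3000 nM
- compound 3 `CC(c1ccccc1)N1CCN(c2c(Cl)cnc3[nH]c(-c4ccc(N(C)C)cc4)nc23)CC1` gives 900 nM

Compound 2 stands highest of the three, and its gaps to compound 1 and compound 3 both lie beyond the scatter. It is also the only one of the three with an unsubstituted phenyl. Compound 4 `CN(C)Cc1ccc(-c2nc3c(N4CCN(CC(=O)Nc5nccs5)CC4)c(Br)cnc3[nH]2)cc1` has not yet been measured. It departs from compound 2 by a single change, ((dimethylamino)methyl in place of hydrogen on an aromatic carbon), which gives a 4-((dimethylamino)methyl)phenyl.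

Within the data shown here, no measured pair isolates this change. With the same 4-((dimethylamino)methyl)phenyl as compound 4, compound 1 gives 230 nM in this assay, but it differs from compound 4 elsewhere too. A step to a lower number, beyond the scatter, is therefore expected, though probably not one reaching the value of compound 1. The expected move is a 5.0-fold lower number from compound 2 to compound 4 (0.70 log units; beyond the scatter), and this remains an estimate. Compound 4 is estimated at 600 nM, with an expected range from 180 nM to 1800 nM in this readout.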

Compound 4, concentration for 50% growth inhibition: 1000 nM
Beside the measured number, compound 4's estimate is 1.7-fold (0.22 log units) below it; low and high end bracket the measured number.
By their numbers in this assay, from the lowest: compound 1; then compounds 3 and 4 (each within the scatter of the next); then compound 2.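

In this assay, (dimethylamino)methyl in place of hydrogen on the phenyl gives a 3.0-fold lower number from compound 2 to compound 4 (0.48 log units; beyond the scatter), so this position affects the number, at least with the (1,3-thiazol-2-yl)carbamoyl side chain in place. With the 4-((dimethylamino)methyl)phenyl held constant, (1,3-thiazol-2-yl)carbamoyl in place of 5-methyl-1,2-oxazol-3-yl gives a 4.3-fold higher number from compound 1 to compound 4 (0.64 log units; beyond the scatter), so the low number of compound 1 does not rest on the phenyl substituent alone. Nothing available bears on the cause of either step.

As far as these compounds go, the phenyl change is read against one side chain only, so whether it carries over to the 5-methyl-1,2-oxazol-3-yl side chain stays open. Also open, from the compounds shown here alone, is how a morpholin-4-ylmethyl group or a carboxylic acid at the same place on the phenyl would read.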